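Pyridazine for pyrimidine in a sparingly soluble amine series

A few compounds are considered here, and "the series" means these few. Any claim that something is new, unique, unknown or untested is made for them only; others in the source may bear on it.

Compound 1, `COc1cccc(Nc2cc3[nH]c(-c4cccc(C(F)(F)F)c4)nc3cn2)n1`: in a physicochemical assay for solubility, using the shake flask method, in phosphate buffer, measured as kinetic solubility, with a stated time of 20 h, at pH 6.5 (a lower number here means a less soluble compound, a higher number a more soluble compound), compound 1 gives < 5000 nM, a limit of the assay and not a number.
Compound 2, `COc1cccnc1Nc1cc2[nH]c(-c3cccc(C(F)(F)F)c3)nc2cn1`: compound 2 gives < 5000 nM, again a limit.
Compound 3, `FC(F)(F)c1cccc(-c2nc3cnc(Nc4ccncn4)cc3[nH]2)c1`: compound 3 gives < 5000 nM, again a limit.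

Compound 3 therefore stands where every measured compound stands: at the limit of < 5000 nM in this assay, at which 3 of the 3 values shown sit. The change from compound 1 to compound 3, a step that the two limits leave unreadable from compound 1 to compound 3, and the change from compound 2 to compound 3, a step that the two limits leave unreadable from compound 2 to compound 3, cannot be sized, because both ends are limits.

Compound 4, `FC(F)(F)c1cccc(-c2nc3cnc(Nc4cccnn4)cc3[nH]2)c1`, differs from compound 3 only by pyridazin-3-yl in place of pyrimidin-4-yl on a nitrogen on an aromatic ring. The measured steps that bear on this kind of swap are those just named, and none of them gives a readable size, so no direction can be taken from them. The expectation is that the step from compound 3 to compound 4 is a step that the limit leaves unreadable from compound 3 to compound 4, with compound 4 most likely reported again as a limit. Compound 4 is estimated at 1500 nM, in the range 100 nM to 8000 nM.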

Compound 4, solubility: < 5000 nM
Compound 4 was reported as a limit (the forecaster's own chance of this, stated with the estimate: 80%); the middle value does not contradict the limit.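

Compound 4 is again a limit and not a number, so its steps from compound 1, compound 2 and compound 3 cannot be read, as all four compounds sit together: the limit of < 5000 nM in this assay, at which 4 of the 4 values shown sit.

The compounds shown leave open how the true solubilities of these four compounds compare, including whether pyridazin-3-yl and pyrimidin-4-yl differ at all.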